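The source may hold more compounds than are shown below. What is called first, only, known or untested is meant among the compounds shown, and "the series" means these compounds.

Measured compounds in this set:

Compound 1, `COc1ccc(Oc2ccccc2-c2ccsc2S(=O)(=O)N2CCN(C(=O)Nc3ccc([N+](=O)[O-])cc3)CC2)cc1OC`, in a functional assay on HeLa cells (Homo sapiens) for inhibition, read by CCK-8 assay, with a stated time of 48 h (on this read-out lower numbers stand for stronger inhibition and higher numbers for weaker inhibition), gives > 50000 nM, which is a limit of the assay and not a number.
Compound 2, `Cc1cc(C)cc(NC(=O)NCCNS(=O)(=O)c2ccc(-c3ccccc3OCc3ccccc3)s2)c1`, in this assay gives > 50000 nM, again a limit rather than a number.
Compound 3, `COc1ccc(Oc2ccc([N+](=O)[O-])cc2-c2ccsc2S(=O)(=O)N2CCN(C(=S)Nc3ccc([N+](=O)[O-])cc3)CC2)cc1OC`, in this assay gives > 50000 nM, also a limit.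

Compound 3 therefore stands at the limit, together with the other two: the limit of > 50000 nM in this assay, at which 3 of the 3 values shown sit. For the measured compounds named here, no pair of measured compounds differs in only one place, so no single measured step is available.

Compound 4, `COc1ccc(Oc2ccc([N+](=O)[O-])cc2-c2ccsc2S(=O)(=O)N2CCN(C(=O)Nc3ccc([N+](=O)[O-])cc3)CC2)cc1OC`, is not yet measured. It differs from compound 3 in a single place: a group of 12 heavy atoms (7 carbon, 2 nitrogen, 3 oxygen; one six-membered aromatic ring of carbon only) in place of a group of 12 heavy atoms (7 carbon, 2 nitrogen, 2 oxygen, 1 sulfur; one six-membered aromatic ring of carbon only), on an amine nitrogen in a ring

Going by the values given here, since every value shown so far is a limit, there is no measured step from which the size of this change can be read. The expectation is that compound 4 stays where compound 3 stands, with no step beyond the usual scatter, and most likely a limit reported again. The step of a number no higher from compound 3 to compound 4 (the limit leaves the size open) is thus expected to be essentially none. Compound 4 is estimated at 50000 nM, within a range from 20000 nM to 100000 nM, with a limit the most probable outcome.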

Compound 4, half-maximal inhibitory concentration: > 50000 nM
Compound 4 was reported as a limit; the forecaster's own chance of this, stated with the estimate: 80%; the middle value lies on the limit itself.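

Compound 4 adds no readable step: its links to compound 3 and to compound 1 each join two limits, so neither step can be read in size. In this assay the compounds shown leave open which change to the shared core, if any, would give a measured number rather than a limit.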